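Primary amide to dimethylamide on the shared core

The compounds below may be only part of what the source reports. "The series", "measured", "known", "first", "only" and "open" are said of these compounds alone.

Measured so far in an assay on isolated protein for inhibition of Apoptosis regulator Bcl-2 (Homo sapiens), read by fluorescence polarization, with stated times of 5 min and 10 min; on this read-out lower numbers stand for stronger inhibition and higher numbers for weaker inhibition:
- compound 1 `CC(C)=CCCC1=CC[C@H](C(=O)Nc2ccc(O)cc2)[C@@H](c2ccccc2)C1`: in this assay compound 1 gives > 23000 nM, which is a limit of the assay.
- compound 2 `CC(C)=CCCC1=CC[C@H](C(N)=O)[C@@H](c2ccccc2)C1`: in this assay compound 2 gives > 23000 nM, again a limit of the assay.

Compound 2 thus stands at the limit of this assay, with no number behind it; both values shown sit at that limit (the limit of > 23000 nM in this assay, at which 2 of the 2 values shown sit). Within the data shown here, the single measured step, a step that the two limits leave unreadable from compound 1 to compound 2, is unreadable between the two limits, so the measured data set no size for any change at the carbonyl. Compound 3 `CC(C)=CCCC1=CC[C@H](C(=O)N(C)C)[C@@H](c2ccccc2)C1` differs from compound 2 by dimethylamino in place of amino on a carbonyl carbon. With no readable step to lean on, the expectation for compound 3 in this assay is that it stays in the limit region; the estimated step that the limit leaves unreadable from compound 2 to compound 3 is therefore taken as none beyond the scatter. The estimate for compound 3 is 30000 nM, with a range from 10000 nM to 100000 nM, most likely reported as another limit.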

Compound 3, inhibition constant: > 23000 nM
Compound 3 was reported as a limit (the forecaster's own chance of this, stated with the estimate: 85%); the middle value does not contradict the limit.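

In this assay compound 3 gives > 23000 nM, a limit of the assay, so the steps linking compound 1, compound 2 and compound 3 cannot be read: the limit of > 23000 nM in this assay, at which 3 of the 3 values shown sit.

The compounds shown leave open whether any group on the carbonyl of the shared core gives a numerical inhibition constant in this assay.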